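The compounds below may be only part of what the source reports. "The series", "measured", "known", "first", "only" and "open" are said of these compounds alone.

In an assay on HEK293 cells for displacement of a labelled ligand from prostaglandin D2 receptor 2 (Homo sapiens) (a higher number here means a weaker inhibitor, a lower number a stronger inhibitor), compound 1 `O=C(O)Cn1c(SCc2ccccc2Cl)nc2ccccc21` gives 370 nM. Compound 2 `Cc1ccccc1CSc1nc2ccccc2n1CC(=O)O` gives 810 nM in this assay, and compound 3 `COc1ccc(C)cc1CSc1nc2ccccc2n1CC(=O)O` gives 1200 nM. Compound 1 differs from compound 2 by chloro in place of methyl on an aromatic carbon, and this step brought a 2.2-fold lower number from compound 2 to compound 1 (0.34 log units; beyond the scatter). The difference between the cores of compound 3 and compound 2 is not broken down here. Compound 4 `COc1ccc(Cl)cc1CSc1nc2ccccc2n1CC(=O)O` has not been measured; it differs from compound 3 by chloro in place of methyl on an aromatic carbon. This is the same kind of change as from compound 2 to compound 1, but not the same: here the place is meta to a large group and para to a methoxy group, whereas before it was ortho to a large group. A step of similar size is expected due to a 2.2-fold lower number from compound 2 to compound 1 (0.34 log units; beyond the scatter), namely a 2.0-fold lower number from compound 3 to compound 4 (0.30 log units; within the scatter). Compound 4 is therefore estimated at 600 nM, expected to lie between 300 nM and 1200 nM.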

Compound 4, half-maximal inhibitory concentration: 740 nM
For compound 4 the middle estimate is 1.2-fold (0.09 log units) below the measured one; the measured number falls inside the stated range.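

In this assay chloro in place of methyl gives a 1.6-fold lower number from compound 3 to compound 4 (0.21 log units; within the scatter) and this step on its own cannot be told apart from the scatter. Set beside the earlier step on the other core, it does not differ from it: the same change on two cores in this assay, a 2.2-fold lower number (0.34 log units; beyond the scatter) from compound 2 to compound 1 and a 1.6-fold lower number (0.21 log units; within the scatter) from compound 3 to compound 4, 1.4-fold (0.13 log units) apart, within the scatter of two such steps. The change therefore carries over consistently across these two pairs, but two pairs cannot show that it will hold on further cores, and the second step alone does not establish a real gain.

The compounds shown leave open whether a bromo or a nitrile in the same place would behave like chloro. Going by these compounds, it also remains open whether the step would survive on a core carrying an ethoxy group instead of the methoxy group.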